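Aryl replacement on the shared core, towards compound 4

This account rests on a few compounds, and the source may have more. Where it says the series, first, only, none or still open, it means among the compounds named here.

Measured so far:
compound 1 `c1ccc(-c2cnoc2)c(NCC2=NCCN2)c1` gives 45.7 nM
compound 2 `c1cnc(-c2ccccc2NCC2=NCCN2)nc1` gives 10 nM
compound 3 `FC(F)(F)c1cccnc1-c1ccccc1NCC1=NCCN1` gives 676 nM

All three compounds carry the same core and differ only in the aromatic group attached to it. Read in a functional assay for activation of Alpha-1A adrenergic receptor (Homo sapiens), read by calcium flux (a lower number here means that less compound is needed, a higher number that more compound is needed for the effect), compound 1 stands second highest of the three numbers: compound 2 lies nearest, with the 1,2-oxazol-4-yl exchanged for pyrimidin-2-yl, a change that gave a 4.6-fold lower number from compound 1 to compound 2 (0.66 log units; beyond the scatter); compound 3 lies furthest, and its number beside that of compound 1 shows a much higher value for the trifluoromethyl-bearing pyridyl group, beyond the scatter.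

Compound 4 `CO/N=C/c1ccccc1NCC1=NCCN1` takes the same position on the core but drops the ring altogether: a group of 4 heavy atoms (2 carbon, 1 nitrogen, 1 oxygen; no ring) in place of a group of 5 heavy atoms (3 carbon, 1 nitrogen, 1 oxygen; one five-membered aromatic ring with 2 hetero atoms), on an aromatic carbon. For the measured compounds named here, no measured step covers a ring-to-chain exchange at this place. Going by the values given here, the only step that bears on it, the modest one from compound 1 to compound 2, concerns a ring-for-ring swap and therefore says little about an open chain. The spread between compound 2 and compound 3 marks how wide the outcome can be.

Without a closer precedent, compound 4 is expected to land near compound 1, the step of a 1.3-fold higher number from compound 1 to compound 4 (0.12 log units; within the scatter) lying within the scatter in either direction; the estimate is 60 nM with a range from 15 nM to 250 nM.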

Compound 4, half-maximal effective concentration: 51.3 nM
Compound 4: middle estimate off by 1.2-fold (0.07 log units), on the high side, and the stated range covers the measured number.
By their numbers in this assay, from the lowest: compound 2; then compounds 1 and 4 (each within the scatter of the next); then compound 3.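

In this assay, a ring is not required at this place on the shared core: a 1.1-fold higher number from compound 1 to compound 4 (0.05 log units; within the scatter), so the open group of 4 heavy atoms, with no ring and 1 double bond outside aromatic rings, stands level with 1,2-oxazol-4-yl. That level does not reach the one set by pyrimidin-2-yl, with a 5.1-fold higher number from compound 2 to compound 4 (0.71 log units; beyond the scatter), which places an open chain on the same scale as the ring-for-ring comparison and leaves compound 2 with the lowest number of the three. No supporting measurement bears on either step.

Going by these compounds, it remains open whether the match between compound 1 and compound 4 extends to other open groups at this place, such as a longer chain, an amine or a carboxylic acid. Compound 2 carries both a six-membered ring and 2 hetero atoms, and the measured compounds do not separate the two. A plain phenyl group on the same core would address that question.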